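Methoxy for Chloro, Tried a Second Time

The compounds below may be only part of what the source reports. "The series", "measured", "known", "first", "only" and "open" are said of these compounds alone.

Measured so far in a functional assay on PC-3 cells (Homo sapiens) for cytotoxicity, read by MTT assay, with a stated time of 72 h; on this read-out lower numbers stand for stronger inhibition and higher numbers for weaker inhibition:
compound 1 `O=C(Nc1nc2ccc(Cl)cc2s1)c1cn(-c2ccccc2)nc1-c1ccccc1`, 3690 nM
compound 2 `COc1ccc2nc(NC(=O)c3cn(-c4ccccc4)nc3-c3ccccc3)sc2c1`, 17500 nM
compound 3 `O=C(Nc1nc2ccc(Cl)cc2s1)c1cn(-c2ccccc2)nc1-c1ccc(Cl)cc1`, 3230 nM

The change from compound 1 to compound 2 is methoxy in place of chloro on an aromatic carbon and it produced a 4.7-fold higher number from compound 1 to compound 2 (0.68 log units; beyond the scatter) in this assay. Compound 3 differs from compound 1 in its core by chloro in place of hydrogen on an aromatic carbon, which gave a 1.1-fold lower number from compound 1 to compound 3 (0.06 log units; within the scatter). Compound 4 `COc1ccc2nc(NC(=O)c3cn(-c4ccccc4)nc3-c3ccc(Cl)cc3)sc2c1` has not been measured. It differs from compound 3 by methoxy in place of chloro on an aromatic carbon, the same change as from compound 1 to compound 2, made at a place described in the same words. Compound 4 is therefore expected to show a 4.6-fold higher number from compound 3 to compound 4 (0.67 log units; beyond the scatter) in this assay, a step of similar size, because a 4.7-fold higher number from compound 1 to compound 2 (0.68 log units; beyond the scatter) was seen once already. Compound 4 is estimated at 15000 nM in this assay, with an expected range from 7000 nM to 35000 nM.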

Compound 4, half-maximal inhibitory concentration: 29300 nM
Compound 4: middle estimate off by 2.0-fold (0.29 log units), on the low side; low and high end bracket the measured number.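

In this assay, methoxy in place of chloro again gave a higher number (a 9.1-fold higher number from compound 3 to compound 4 (0.96 log units; beyond the scatter)), and the two steps for this change do not differ beyond the scatter: the same change on two cores in this assay, a 4.7-fold higher number (0.68 log units; beyond the scatter) from compound 1 to compound 2 and a 9.1-fold higher number (0.96 log units; beyond the scatter) from compound 3 to compound 4, 1.9-fold (0.28 log units) apart, within the scatter of two such steps. Chloro in place of hydrogen also carried over, with its new step (a 1.7-fold higher number from compound 2 to compound 4 (0.22 log units; within the scatter)) agreeing with the earlier one: the same change on two cores in this assay, a 1.1-fold lower number (0.06 log units; within the scatter) from compound 1 to compound 3 and a 1.7-fold higher number (0.22 log units; within the scatter) from compound 2 to compound 4, 1.9-fold (0.28 log units) apart, within the scatter of two such steps. Among the compounds shown here, this shows that both changes behaved consistently across these two cores in this one assay, but with only two pairs for each change, it does not show that they would do so on other cores.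

The compounds shown leave open how an amine or a carboxylic acid would compare with chloro and methoxy on that aromatic carbon. They also leave open whether these steps would hold on other cell lines.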